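Aminopyridazine in place of methylthiazole: expected lipophilicity

The source may report more compounds than this note shows. Statements on the series, on what has been measured and on what is new or still open speak of the compounds shown alone.

Measured so far in a physicochemical assay for lipophilicity; on this read-out lower numbers stand for lower lipophilicity and higher numbers for higher lipophilicity:
Compound 1, `Cc1cc(Cl)c(-c2cn(C)c(C)n2)cc1NC(=O)c1ccc(OCc2ccccn2)cc1`, gives 3.3.
Compound 2, `Cc1ccc(-c2ncc[nH]2)c(C)c1NC(=O)c1ccc(OCc2ccccn2)cc1`, gives 2.8.
Compound 3, `Cc1csc(-c2cc(NC(=O)c3ccc(OCc4ccccn4)cc3)c(C)cc2C)n1`, gives only a limit of the assay, > 3.

Among the measured compounds shown here, of the three, compound 3 is the one without a definite number; its value is a limit, (the limit of > 3 in this assay, at which 1 of the 3 values shown sits). Compound 4, `Cc1cc(C)c(-c2ccc(N)nn2)cc1NC(=O)c1ccc(OCc2ccccn2)cc1`, has not yet been measured. It differs from compound 3 by 6-aminopyridazin-3-yl in place of 4-methyl-1,3-thiazol-2-yl on an aromatic carbon.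

For the measured compounds named here, no step between two measured compounds is available as a guide. Since the entering group carries a hydrogen-bond donor and an additional hydrogen-bond acceptor, a step in this assay toward lower numbers, clearly beyond the scatter, is expected; the expected step is a number at least 0.60 log units lower from compound 3 to compound 4 (beyond the scatter). For compound 4 the estimate in this assay is 2.4, within a range from 1.8 to 3.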

Compound 4, distribution coefficient: 2.6
For compound 4 the middle estimate is 0.20 log units below the measured one; the measured number falls inside the stated range.
By their numbers in this assay, from the lowest: compounds 4 and 2 (each within the scatter of the next); then compound 1.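

In this assay, 6-aminopyridazin-3-yl in place of 4-methyl-1,3-thiazol-2-yl, on an aromatic carbon ortho to a methyl group and para to a methyl group, gives a number at least 0.40 log units lower from compound 3 to compound 4 (beyond the scatter). Among the compounds shown here, this is the first step with only one place changed, so it shows that the read-out responds to the group at this position. Compound 3 carries only a limit of the assay, so the step has a lower bound and no exact size: the limit of > 3 in this assay, at which 1 of the 4 values shown sits.

Going by these compounds, whether the step belongs to the amine or to the ring that carries it stays open. A plain pyridazine, or a methoxy group in place of the amine, would separate the two.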